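Sulfonamide pair at the binding limit; third analogue pending

A few compounds are considered here, and "the series" means these few. Any claim that something is new, unique, unknown or untested is made for them only; others in the source may bear on it.

compound 1, `CCN(CC)S(=O)(=O)c1ccc(NC(=O)c2ccccc2)c2ccccc12`: > 30000 nM
compound 2, `CN1CCN(S(=O)(=O)c2ccc(NC(=O)c3ccccc3)c3ccccc23)CC1`: > 30000 nM

In an assay on L1.2 cells for binding affinity to C-C chemokine receptor type 8 (Homo sapiens) (a higher number here means a weaker inhibitor, a lower number a stronger inhibitor), compound 1 gives > 30000 nM, which is a limit of the assay, not a number. Compound 2 gives > 30000 nM, likewise a limit. The step that the two limits leave unreadable from compound 1 to compound 2 is therefore unreadable; both values sit at the limit of > 30000 nM in this assay, at which 2 of the 2 values shown sit. Compound 3 `O=C(Nc1ccc(S(=O)(=O)NC2CCCCC2)c2ccccc12)c1ccccc1` differs from compound 2 by cyclohexylamino in place of 4-methylpiperazin-1-yl on a sulfonyl sulfur. Going by the values given here, no measured step bears on this change, and neither value shown is a number, so no direction can be read from the series. Compound 3 is expected to remain at the limit, estimated at 30000 nM (range 10000 nM to 100000 nM). The expected step of a number no higher from compound 2 to compound 3 (the limit leaves the size open) is none beyond the scatter.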

Compound 3, inhibition constant: 4.4 nM
Compound 3: middle estimate off by 6800-fold (3.83 log units), on the high side; measured number outside the range, below it.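

Cyclohexylamino on the sulfonyl sulfur brings an at least 6800-fold lower number from compound 2 to compound 3 (3.83 log units; beyond the scatter) and an at least 6800-fold lower number from compound 1 to compound 3 (3.83 log units; beyond the scatter) on the shared core, so the group at this position can decide whether binding is seen at all. Cyclohexylamino and 4-methylpiperazin-1-yl have the same heavy-atom count and both hold a six-membered non-aromatic ring, so neither feature alone separates them; they differ in the ring hetero atoms and the hydrogen-bond donor. Both steps give only a minimum size: the limit of > 30000 nM in this assay, at which 2 of the 3 values shown sit.

Going by these compounds, it remains open whether the hydrogen-bond donor or the all-carbon ring matters. Piperidin-1-yl, which has the carbon ring without that donor, would separate the two, and cyclopentylamino would test ring size.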